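Estimating Cytotoxicity for a Benzamido Analogue

The source may hold more compounds than are shown below. What is called first, only, known or untested is meant among the compounds shown, and "the series" means these compounds.

Compound 1 `O=C(Nc1nc(-c2ccccc2)cs1)c1ccc([N+](=O)[O-])o1` was tested in an ADME assay on Vero cells (Chlorocebus sabaeus) for cytotoxicity, read by MTT assay, with a stated time of 72 h (a lower number here means a stronger inhibitor, a higher number a weaker inhibitor), where compound 1 gives 41700 nM, the lowest of the two numbers available. Compound 2 `O=C(Nc1nc(-c2cccc(Br)c2)cs1)c1ccc([N+](=O)[O-])o1`, carrying bromo in place of hydrogen on an aromatic carbon, gives 71000 nM; the step of a 1.7-fold higher number from compound 1 to compound 2 (0.23 log units; within the scatter) stays within the scatter. For compound 3 `O=C(Nc1nc(-c2cccc(NC(=O)C3CCC3)c2)cs1)c1ccc([N+](=O)[O-])o1` the result is "not determined" (no result reported).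

Compound 4 `O=C(Nc1cccc(-c2csc(NC(=O)c3ccc([N+](=O)[O-])o3)n2)c1)c1ccccc1` differs from compound 1 by benzamido in place of hydrogen on an aromatic carbon. Going by the values given here, the only step that bears on this change is the one from compound 1 to compound 2, where adding a group on an aromatic carbon barely moved the number. No step beyond the scatter is therefore expected here. Compound 4 is estimated to give 48000 nM, within a range of 16000 nM to 140000 nM. The expected step of a 1.2-fold higher number from compound 1 to compound 4 (0.06 log units; within the scatter) is accordingly small.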

Compound 4, half-maximal inhibitory concentration: 50200 nM
Compound 4: middle estimate off by 1.0-fold (0.02 log units), on the low side; the range from low to high includes it.
By their numbers in this assay, from the lowest: compounds 1, 4 and 2 (each within the scatter of the next).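

In this assay a group as large as benzamido, with its own six-membered aromatic ring, can sit on this aromatic carbon and still leave the reading within the scatter, with a 1.2-fold higher number from compound 1 to compound 4 (0.08 log units; within the scatter) in the assay. Putting benzamido in place of bromo gives a 1.4-fold lower number from compound 2 to compound 4 (0.15 log units; within the scatter), so these two very different groups cannot be told apart here. Nothing measured here explains this flat picture.

As far as these compounds go, whether an amine or a carboxylic acid on this same aromatic carbon would also stay within the scatter remains open.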